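Geometry of an Exocyclic Double Bond and Cell Growth

The compounds below may be only part of what the source reports. "The series", "measured", "known", "first", "only" and "open" are said of these compounds alone.

Measured so far:
compound 1, `C=C(Br)C(=O)Nc1ccc2c(c1)/C(=C\c1cccs1)C(=O)N2`: 15 nM
compound 2, `C=C(Br)C(=O)Nc1ccc2c(c1)/C(=C/c1ccc(C)s1)C(=O)N2`: 24 nM

In a functional assay on HL-60 cells (Homo sapiens) for antiproliferative activity, read by MTT assay, with a stated time of 72 h (on this read-out lower numbers stand for stronger inhibition and higher numbers for weaker inhibition), compound 1 gives 15 nM and compound 2 gives 24 nM. Compound 2 has the higher of the two numbers, but its gap to compound 1 lies within the scatter, so no order between them can be claimed. Compound 3, `C=C(Br)C(=O)Nc1ccc2c(c1)/C(=C\c1ccc(C)s1)C(=O)N2`, is yet to be measured. It differs from compound 2 in this way: the two compounds have the same atoms and bonds and differ only in configuration as drawn: 1 of 1 stereo elements differ; a double bond is drawn Z in compound 2 and E in compound 3. For the measured compounds named here, with no measured pair of this kind to lean on, the step from compound 2 to compound 3 in this assay is expected to stay within the scatter, a 1.2-fold lower number from compound 2 to compound 3 (0.08 log units; within the scatter). Compound 3 is therefore estimated at 20 nM, between 6 nM and 70 nM.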

Compound 3, half-maximal inhibitory concentration: 12 nM
Compound 3: middle estimate off by 1.7-fold (0.22 log units), on the high side; the measured number falls inside the stated range.
By their numbers in this assay, from the lowest: compounds 3, 1 and 2 (each within the scatter of the next).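

In this assay, the geometry of the double bond now has a measured pair, with a 2.0-fold lower number from compound 2 to compound 3 (0.30 log units; within the scatter), so the change of configuration as drawn does not carry the number beyond the scatter here. Methyl in place of hydrogen on an aromatic carbon also stays within the scatter, with a 1.3-fold lower number from compound 1 to compound 3 (0.10 log units; within the scatter). The first of these steps reads that one stereo element alone, the ground for this being: the fact that compounds 2 and 3 differ only in the configuration as drawn

From the compounds shown here alone, whether an amine or a carboxylic acid on that aromatic carbon would shift the number stays open. The effect of geometry without the methyl is open too, as compound 1 stands here without a partner of the opposite geometry.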